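This account rests on a few compounds, and the source may have more. Where it says the series, first, only, none or still open, it means among the compounds named here.

Measured compounds:
compound 1 `CCCN(c1nc(-c2ccc(Br)cc2C)n(C)n1)C(C1CC1)C1CC1` gives 10 nM
compound 2 `CCCN(c1nc(-c2ccc(Cl)cc2Cl)nn1C)C(C1CC1)C1CC1` gives > 10000 nM, a limit rather than a number

Among the measured compounds shown here, in an assay on CHO cells for binding affinity to corticotropin-releasing factor receptor 1 (Homo sapiens) (a lower number here means a stronger inhibitor, a higher number a weaker inhibitor), compound 1 gives 10 nM, the only value in this set that is a number. Compound 2 gives > 10000 nM in this assay; this is a limit of the assay, not a measured number (the limit of > 10000 nM in this assay, at which 1 of the 2 values shown sits). For the measured compounds named here, no pair of measured compounds differs in one place only, so there is no measured step to set a scale, and compound 1 stands alone as the reference point.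

Compound 3 `CCCN(c1nc(-c2ccc(Cl)cc2)n(C)n1)C(C1CC1)C1CC1` has not yet been measured. It differs from compound 1 in one place: 4-chlorophenyl in place of 4-bromo-2-methylphenyl on an aromatic carbon. Going by the values given here, with no measured step to lean on, the size of the change can only be estimated. He expects compound 3 to lose affinity relative to compound 1 by more than the usual scatter, a step of a 12-fold higher number from compound 1 to compound 3 (1.08 log units; beyond the scatter). For compound 3 he therefore estimates 120 nM in this assay, within a range from 20 nM to 1500 nM.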

Compound 3, inhibition constant: 33 nM
The estimate for compound 3 lay 3.6-fold (0.56 log units) above the measured number, and the stated range covers the measured number.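

In this assay, the aromatic carbon between two ring nitrogen atoms accepts a change of its aryl group: 4-chlorophenyl in place of 4-bromo-2-methylphenyl gives a 3.3-fold higher number from compound 1 to compound 3 (0.52 log units; beyond the scatter) and so only a modest loss of affinity. The methyl group and the bromine on the phenyl ring are therefore not both required for affinity in this series. The step joins two changes in one, the loss of the methyl group and chlorine in place of bromine, so it assigns no share to either.

On these data alone, how a 4-bromophenyl group, a 4-chloro-2-methylphenyl group or a phenyl ring carrying an amine would fare at this place stays open. Nothing shown here accounts for the size of this step.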